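The source may report more compounds than this note shows. Statements on the series, on what has been measured and on what is new or still open speak of the compounds shown alone.

Compound 1 `CC(C)(C)OC(=O)NCCCCNC(=O)CN1CN(c2ccccc2)C2(CCN(C(=O)c3ccc(C(C)(C)C)cc3)CC2)C1=O`, compound 2 `CC(C)(C)c1ccc(C(=O)N2CCC3(CC2)C(=O)N(CC(=O)NCCC(=O)O)CN3c2ccccc2)cc1` and compound 3 `CC(C)(C)c1ccc(C(=O)N2CCC3(CC2)C(=O)N(CC(=O)NCCO)CN3c2ccccc2)cc1` share one core and differ only in the group attached to a carbonyl carbon whose other neighbour is a saturated chain carbon. In an assay on HEK293 cells for displacement of a labelled ligand from NPC1-like intracellular cholesterol transporter 1 (Homo sapiens) (a lower number here means a stronger inhibitor, a higher number a weaker inhibitor), compound 1 has "not determined" (no result reported) as its result. Compound 2 gives 11400 nM. Compound 3 gives 1000 nM, the lowest of the two numbers that exist; the step of an 11-fold lower number from compound 2 to compound 3 (1.06 log units; beyond the scatter) is large, with a hydroxy in place of a carboxy on the chain.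

Compound 4 `CC(C)(C)c1ccc(C(=O)N2CCC3(CC2)C(=O)N(CC(=O)N2CCCCC2CCO)CN3c2ccccc2)cc1` has not yet been measured. It differs from compound 3 in one place: 2-(2-hydroxyethyl)piperidin-1-yl in place of (2-hydroxyethyl)amino on a carbonyl carbon. Among the compounds with values here, no measured step repeats this kind of change. Within the data shown here, the single step of an 11-fold lower number from compound 2 to compound 3 (1.06 log units; beyond the scatter) swaps one end group for another on an open chain, whereas compound 4 keeps the hydroxyethyl chain and brings in the 2-(2-hydroxyethyl)piperidin-1-yl ring with one fewer hydrogen-bond donor. That step shows only that this region of the molecule matters for the number, not which way a ring would move it. The expectation is therefore a step of uncertain direction, probably small. Compound 4 is expected to give 2000 nM, within 500 nM to 8000 nM, an estimated step of a 2.0-fold higher number from compound 3 to compound 4 (0.30 log units; within the scatter).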

Compound 4, half-maximal inhibitory concentration: 6100 nM
The estimate for compound 4 lay 3.1-fold (0.48 log units) below the measured number; the range from low to high includes it.
By their numbers in this assay, from the lowest: compound 3; then compounds 4 and 2 (each within the scatter of the next).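

In this assay, within the data shown here, the earlier compounds showed only that changing the end group of an open chain moves the number, and the step of a 6.1-fold higher number from compound 3 to compound 4 (0.79 log units; beyond the scatter) adds that keeping a hydroxyethyl chain is not enough to hold the number at this carbonyl carbon. The step of a 1.9-fold lower number from compound 2 to compound 4 (0.27 log units; within the scatter) stays within the scatter, so compound 4, with its hydroxy group on a ring-bearing chain, cannot be told apart from compound 2, with its carboxy group, and the advantage seen for compound 3 does not carry over to this ring. The change adds a six-membered non-aromatic ring and takes the count of hydrogen-bond donors from 2 to 1, and nothing measured here separates these two differences or explains the step.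

On these data alone, what remains open is whether the ring or the loss of the amide hydrogen matters more, which a compound with a (2-hydroxyethyl)(methyl)amino group could help to separate. A plain piperidin-1-yl group, or a 3-hydroxypropylamino group as a longer open chain, would also show how much the hydroxy group and the length of the chain contribute at this position.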